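A few compounds are considered here, and "the series" means these few. Any claim that something is new, unique, unknown or untested is made for them only; others in the source may bear on it.

Measured so far:
- compound 1, `O=C(/C=C/c1ccc2c(c1)B(O)OC2)c1ccc(I)cc1`, in a functional assay on MDA-MB-231 cells (Homo sapiens) for cytotoxicity, read by MTT assay, with a stated time of 48 h (a higher number here means a weaker inhibitor, a lower number a stronger inhibitor), gives 14900 nM
- compound 2, `O=C(/C=C/c1ccc2c(c1)B(O)OC2)c1cccc(F)c1`, in this assay gives 3000 nM

Going by the values given here, compound 2 stands at the lowest of the two numbers in this assay; the nearest is compound 1, and the only measured step is a 5.0-fold lower number from compound 1 to compound 2 (0.70 log units; beyond the scatter). That step swaps the whole substituted aromatic ring on the carbonyl carbon and does not touch the place now in question.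

Compound 3, `COc1cccc(C(=O)/C=C/c2ccc3c(c2)B(O)OC3)c1`, differs from compound 2 by methoxy in place of fluoro on an aromatic carbon. Among the compounds with values here, no measured step exchanges a fluoro for a methoxy at this position, so the step from compound 1 to compound 2 bears on it only loosely, as a sign that this ring influences this assay. For compound 3 a step of a 1.2-fold higher number from compound 2 to compound 3 (0.07 log units; within the scatter) is expected, that is nothing clearly beyond the scatter. The estimate for compound 3 in this assay is 3500 nM, within a range of 1200 nM to 10000 nM.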

Compound 3, half-maximal inhibitory concentration: 2100 nM
Compound 3: middle estimate off by 1.7-fold (0.22 log units), on the high side; measured number inside the range.
By their numbers in this assay, from the lowest: compounds 3 and 2 (each within the scatter of the next); then compound 1.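

At this place, an aromatic carbon meta to a large group, methoxy in place of fluoro gives a 1.4-fold lower number from compound 2 to compound 3 (0.15 log units; within the scatter) in this assay. Compound 2 and compound 3 therefore cannot be told apart in this read-out, so for this pair the change from fluoro to methoxy, with its added heavy atom and hydrogen-bond acceptor, leaves no detectable mark on the number. No available data bear on why the two groups read alike.

Still open, from the compounds shown here alone, is whether this tolerance extends beyond these two groups, for instance to an amine, a carboxylic acid or a longer chain such as butoxy at the same place. The compounds shown also leave open whether fluoro and methoxy would read alike elsewhere on this ring.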